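The compounds below may be only part of what the source reports. "The series", "measured", "known", "first", "only" and "open" are said of these compounds alone.

Measured so far in an ADME assay on MT4 cells (Homo sapiens) for cytotoxicity, read by MTT assay, with a stated time of 96 h; on this read-out lower numbers stand for higher toxicity in this test and higher numbers for lower toxicity in this test:
Compound 1 `CCC(=O)Nc1ccc(-c2nc3cc(C(F)(F)F)ccc3n2C2CCCCC2)cc1` gives 17000 nM.
Compound 2 `CCC(=O)Nc1ccc(-c2nc3cc(C(F)(F)F)ccc3[nH]2)cc1` reaches only the assay limit of >= 100000 nM.
Compound 3 `CCC(=O)Nc1ccc(-c2nc3cc(C(F)(F)F)ccc3n2C)cc1` gives 8000 nM.

Among the two compounds that give a number, compound 1 stands highest; compound 3 is its nearest neighbour, a 2.1-fold lower number from compound 1 to compound 3 (0.33 log units; beyond the scatter), a step beyond the scatter. All three measured steps concern the group on the aromatic nitrogen of the shared core: an at least 5.8-fold higher number from compound 1 to compound 2 (0.76 log units; beyond the scatter), an at least 12-fold lower number from compound 2 to compound 3 (1.09 log units; beyond the scatter) and the step just named. The value of compound 2 is a limit (the limit of >= 100000 nM in this assay, at which 1 of the 3 values shown sits), which is why the steps to and from it are bounded rather than exact.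

Compound 4 `Nc1ccc(-c2nc3cc(C(F)(F)F)ccc3n2C2CCCCC2)cc1` is not yet measured. It differs from compound 1 at another place: hydrogen in place of propanoyl on a nitrogen on an aromatic ring. Going by the values given here, no measured step touches this nitrogen, and nothing measured bears directly on this change. The expectation therefore rests on compound 1 alone, and a step no larger than the scatter is expected, no change at the digits printed from compound 1 to compound 4 (within the scatter). Compound 4 is estimated at 17000 nM, with a range from 6000 nM to 50000 nM.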

Compound 4, half-maximal cytotoxic concentration: 44000 nM
For compound 4 the middle estimate is 2.6-fold (0.41 log units) below the measured one; the measured number falls inside the stated range.
By their numbers in this assay, from the lowest: compound 3; then compound 1; then compound 4. At a limit, above all of these: compound 2.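

In this assay, the change from propanoylamino to amino gives a 2.6-fold higher number from compound 1 to compound 4 (0.41 log units; beyond the scatter). The nitrogen on the aromatic ring is therefore a second place on the shared core, alongside the aromatic nitrogen, where a single change moves the number beyond the scatter. Since a higher number stands for lower toxicity in this test, the free amino compound is the less toxic of this pair, although this rests on one pair carrying cyclohexyl.

From the compounds shown here alone, it remains open whether the same change would act alike with methyl on the aromatic nitrogen, as in compound 3, and where a longer chain such as butanoyl, or a methylsulfonyl group, on the amino nitrogen would fall relative to compound 1 and compound 4. Nothing measured here gives a reason for this step.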